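Compound 1 to compound 3: nitro replacing methylsulfanyl

The source may hold more compounds than are shown below. What is called first, only, known or untested is meant among the compounds shown, and "the series" means these compounds.

Measured in an ADME assay on L6 cells (Rattus norvegicus) for cytotoxicity, read by resazurin assay, with a stated time of 72 h; a lower number here means a stronger inhibitor, a higher number a weaker inhibitor:
- compound 1 `CSc1ccc(-c2noc(CN3N=N[C@@H]4C(=O)N(c5ccccc5)C(=O)[C@@H]43)n2)cc1`: > 100 ug/mL (a limit, not a number)
- compound 2 `O=C1[C@H]2N=NN(Cc3nc(-c4ccc(I)cc4)no3)[C@H]2C(=O)N1c1ccccc1`: 48.6 ug/mL

Compound 1 stands only as a limit in this assay, at > 100 ug/mL. The same limit marks the top of what has been seen so far: the limit of > 100 ug/mL in this assay, at which 1 of the 2 values shown sits.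

Compound 3 `O=C1[C@H]2N=NN(Cc3nc(-c4ccc([N+](=O)[O-])cc4)no3)[C@H]2C(=O)N1c1ccccc1` keeps the core of compound 1 and changes one group: nitro in place of methylsulfanyl on an aromatic carbon. Among the measured compounds shown here, one measured step bears on this place, the swap of iodo for methylsulfanyl on the same aromatic carbon: an at least 2.0-fold lower number from compound 1 to compound 2 (0.31 log units; beyond the scatter). That step lies beyond the scatter, but its size is only a bound, since compound 1 has no number. For the measured compounds named here, no measured compound carries nitro, so this single step transfers only loosely.

On the strength of an at least 2.0-fold lower number from compound 1 to compound 2 (0.31 log units; beyond the scatter), a move to a lower number of similar size is expected, though compound 3 may also stay at the limit. The expected change is an at least 1.6-fold lower number from compound 1 to compound 3 (0.22 log units; that floor lies within the scatter). Compound 3 is estimated at 60 ug/mL, with an expected range of 25 ug/mL to 110 ug/mL.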

Compound 3, half-maximal inhibitory concentration: > 100 ug/mL
Compound 3: no number, only a limit; the forecaster's own chance of this, stated with the estimate: 35%; middle value at least 1.6-fold (0.22 log units) away from the limit.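

In this assay compound 3 gives > 100 ug/mL, a limit and not a number, and with compound 1 also standing at a limit, the step between these two cannot be read. Nitro in place of iodo on the aromatic carbon gives an at least 2.0-fold higher number from compound 2 to compound 3 (0.31 log units; beyond the scatter), so the lower number seen with iodo does not follow from every replacement of methylsulfanyl at this place, and compound 2 remains the only compound shown with a readable value, 48.6 ug/mL. Two different groups at this place, methylsulfanyl and nitro, now share the top of the range, and the series here reads mostly at the ceiling: the limit of > 100 ug/mL in this assay, at which 2 of the 3 values shown sit.

From the compounds shown here alone, how far compound 1 and compound 3 lie past that limit, and whether they differ from each other at all, stays open. Going by these compounds, whether the lower number of compound 2 is particular to iodo also stays open, and bromo, chloro, an amine or a carboxylic acid at the same aromatic carbon, on the unchanged shared core, would show whether any other group there moves the number off the limit.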